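A few compounds are considered here, and "the series" means these few. Any claim that something is new, unique, unknown or untested is made for them only; others in the source may bear on it.

Two sulfonamides built on one shared core have been measured in a functional assay on A549 cells (Homo sapiens) for antiproliferative activity, read by MTT assay, with a stated time of 24 h; on this read-out lower numbers stand for stronger inhibition and higher numbers for weaker inhibition. Compound 1 `O=c1[nH]cc(S(=O)(=O)Nc2ccccc2-c2cn(-c3ccc(F)cc3)nn2)c(=O)[nH]1` gives 6390 nM. Compound 2 `Cc1ccc(-n2cc(-c3cccc(NS(=O)(=O)c4c[nH]c(=O)[nH]c4=O)c3)nn2)cc1` gives 3630 nM. Of the two numbers, compound 2 carries the lower one, yet its gap to compound 1 lies within the usual scatter of repeated measurements, so the two compounds cannot be told apart on these data. Compound 3 `O=c1[nH]cc(S(=O)(=O)Nc2cccc(-c3cn(-c4ccccc4Cl)nn3)c2)c(=O)[nH]1` has not yet been measured in this assay. It differs from compound 2 in a single place: 2-chlorophenyl in place of 4-methylphenyl on an aromatic nitrogen. Among the compounds with values here, no measured pair shows what such a swap does here, so the step of a 1.1-fold higher number from compound 2 to compound 3 (0.04 log units; within the scatter) is expected to be small, none beyond the scatter. Compound 3 is therefore estimated at 4000 nM, with a likely range from 1500 nM to 11000 nM.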

Compound 3, half-maximal inhibitory concentration: 2730 nM
Beside the measured number, compound 3's estimate is 1.5-fold (0.17 log units) above it, within the range that was stated.
By their numbers in this assay, from the lowest: compounds 3, 2 and 1 (each within the scatter of the next, the first and the last beyond it).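

In this assay, 2-chlorophenyl in place of 4-methylphenyl on an aromatic nitrogen gives a 1.3-fold lower number from compound 2 to compound 3 (0.12 log units; within the scatter). Within the data shown here, this is the first measured swap at this position, and it shows that one phenyl group carrying a chlorine can stand in for another carrying a methyl without moving the number beyond the usual scatter, so compound 2 and compound 3 cannot be told apart on this read-out. No measurement at hand bears on the reason for this result.

From the compounds shown here alone, both groups are substituted phenyl rings with the same count of heavy atoms, so the effect of a very different group here remains open. A carboxylic acid or an amine on the phenyl ring, or a longer alkyl chain in place of that ring, might or might not shift the number beyond the scatter.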